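The source may report more compounds than this note shows. Statements on the series, on what has been measured and on what is new or still open speak of the compounds shown alone.

In a functional assay on A549 cells (Homo sapiens) for inhibition, read by MTT assay, with a stated time of 72 h (a higher number here means a weaker inhibitor, a lower number a stronger inhibitor), compound 2 `COc1cc(O)c(CC=C(C)C)c(O)c1C(=O)/C=C/c1ccc(O)c(O)c1` gives 16100 nM, and compound 1 `COc1cc(/C=C/C(=O)c2c(OC)cc(O)c(CC=C(C)C)c2O)ccc1O` gives 11800 nM. The change between these two, (methyl in place of hydrogen on an oxygen on an aromatic ring), made a step of a 1.4-fold lower number from compound 2 to compound 1 (0.13 log units; within the scatter). Compound 3 `COc1cc(O)cc(O)c1C(=O)/C=C/c1ccc(O)cc1` rests on a different core, and how that core differs from the core of compound 2 is not broken down here. In this assay compound 3 gives only a limit of the assay, > 50000 nM, and not a number; this is the case described by the limit of > 50000 nM in this assay, at which 1 of the 3 values shown sits. Compound 4 `COc1ccc(/C=C/C(=O)c2c(O)cc(O)cc2OC)cc1` has not yet been measured and differs from compound 3 by the same change, (methyl in place of hydrogen on an oxygen on an aromatic ring). The step from compound 3 to compound 4 is expected to be small, a step that the limit leaves unreadable from compound 3 to compound 4, resting on the earlier step of a 1.4-fold lower number from compound 2 to compound 1 (0.13 log units; within the scatter), which lay within the scatter. Compound 4 is therefore expected to give 60000 nM, with a fair chance that only a limit is again reported.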

Compound 4, half-maximal inhibitory concentration: > 50000 nM
Compound 4: no number, only a limit; the forecaster's own chance of this, stated with the estimate: 70%; the middle value does not contradict the limit.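

Going by these compounds alone, compound 3 and compound 4 each give only a limit of the assay, not a number, so no step between them can be read: the limit of > 50000 nM in this assay, at which 2 of the 4 values shown sit. The compounds shown leave open whether hydroxy to methoxy changes inhibition on this core in this assay.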